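Aryl swap on the chain: what to expect for compound 3

The compounds below may be only part of what the source reports. "The series", "measured", "known", "first", "only" and "open" are said of these compounds alone.

Among the measured compounds shown here, in an ADME assay on the whole organism for cytotoxicity, with Artemia salina as the target, with a stated time of 24 h (a lower number here means that less compound is needed, a higher number that more compound is needed for the effect), compound 2 `CCOc1cc(/C=C/C(=O)c2ccccc2NC(=O)NS(=O)(=O)c2ccc(C)cc2)ccc1O` gives 19.2 ug/mL, the lower of the two numbers so far, yet within the scatter of compound 1. Compound 1 `COc1cccc(/C=C/C(=O)c2ccccc2NC(=O)NS(=O)(=O)c2ccc(C)cc2)c1` gives 23.2 ug/mL, and the step of a 1.2-fold lower number from compound 1 to compound 2 (0.08 log units; within the scatter) stays within the scatter. Compound 3 `Cc1ccc(S(=O)(=O)NC(=O)Nc2ccccc2C(=O)/C=C/c2cc(O)ccc2[N+](=O)[O-])cc1` differs from compound 2 by 5-hydroxy-2-nitrophenyl in place of 3-ethoxy-4-hydroxyphenyl on a double-bonded chain carbon bound to a double-bonded chain carbon. For the measured compounds named here, the one measured step, from compound 1 to compound 2, changes the same aryl group and moves nothing beyond the scatter, and no measured step involves a nitro group. The step of a 1.0-fold higher number from compound 2 to compound 3 (0.02 log units; within the scatter) is therefore expected to stay within the scatter. Compound 3 is estimated at 20 ug/mL, range 8 ug/mL to 50 ug/mL.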

Compound 3, concentration for half-maximal effect: 18.3 ug/mL
Beside the measured number, compound 3's estimate is 1.1-fold (0.04 log units) above it, and the stated range covers the measured number.
By their numbers in this assay, from the lowest: compounds 3, 2 and 1 (each within the scatter of the next).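

In this assay, among the compounds shown here, this place on a double-bonded chain carbon bound to a double-bonded chain carbon now accepts 5-hydroxy-2-nitrophenyl, the first aryl group here with a nitro group, and the read-out stays within the scatter: a 1.0-fold lower number from compound 2 to compound 3 (0.02 log units; within the scatter) and a 1.3-fold lower number from compound 1 to compound 3 (0.10 log units; within the scatter). All three aryl groups shown therefore give values within the scatter of one another. Nothing on hand accounts for this.

Open, going by these compounds, is whether an aryl group carrying an amine or a carboxylic acid at this place would move the number beyond the scatter. Also open, on these data alone, is how changes elsewhere on the shared core would read.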